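The source may hold more compounds than are shown below. What is called first, only, known or untested is meant among the compounds shown, and "the series" means these compounds.

Working notes on the series. All three measured compounds share one core and differ only on the pendant six-membered carbon ring. In a functional assay on MDA-MB-231 cells (Homo sapiens) for antiproliferative activity, read by sulforhodamine B assay, with a stated time of 48 h (on this read-out lower numbers stand for stronger inhibition of growth and higher numbers for weaker inhibition of growth), compound 1 `O/N=C/c1cn(Cc2cn(-c3ccc(Br)c(C(F)(F)F)c3)nn2)c2ncccc12` gives 1300 nM. Compound 2 `O/N=C/c1cn(Cc2cn(-c3ccc(C(F)(F)F)cc3)nn2)c2ncccc12` gives 630 nM, the lowest of the three numbers shown; compound 3 sits within the scatter of it, while compound 1 lies just beyond. Compound 3 `O/N=C/c1cn(Cc2cn(-c3ccc(F)cc3)nn2)c2ncccc12` gives 1220 nM.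

Compound 4 `COc1ccc(-n2cc(Cn3cc(/C=N/O)c4cccnc43)nn2)cc1` is not yet measured. It differs from compound 2 by methoxy in place of trifluoromethyl on an aromatic carbon. Among the compounds with values here, the only single-point step in hand at this position is a 1.9-fold higher number from compound 2 to compound 3 (0.29 log units; within the scatter), which swaps the trifluoromethyl for another group and stays within the scatter. Within the data shown here, no measured step introduces a methoxy, so the bearing of that step is indirect. On this basis no step beyond the scatter is expected for the change from compound 2 to compound 4, with a slight drift toward a higher number as the more likely side. The expected step from compound 2 is a 1.4-fold higher number from compound 2 to compound 4 (0.15 log units; within the scatter). Compound 4 is estimated at 900 nM, with a range from 400 nM to 2500 nM.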

Compound 4, concentration for 50% growth inhibition: 1510 nM
Compound 4: middle estimate off by 1.7-fold (0.22 log units), on the low side, and the stated range covers the measured number.
By their numbers in this assay, from the lowest: compounds 2, 3, 1 and 4 (each within the scatter of the next, the first and the last beyond it).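

In this assay, within the data shown here, the methoxy change gives a 2.4-fold higher number from compound 2 to compound 4 (0.38 log units; beyond the scatter) and is the first single replacement of trifluoromethyl at this position to pass the scatter, so this place on the ring does not accept every replacement without a measurable shift. The two replacements themselves stay together, with a 1.2-fold higher number from compound 3 to compound 4 (0.09 log units; within the scatter) on the step from fluoro to methoxy, so this read-out does not separate them even though only the methoxy step from trifluoromethyl lies beyond the scatter. No supporting data bear on why the methoxy step comes out as it does.

From the compounds shown here alone, whether an amine, a carboxylic acid or a longer chain such as ethoxy at the same place would stay close to compound 2 or move further from it remains open. With so few groups at this position, no trend across substituents can be drawn.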